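A few compounds are considered here, and "the series" means these few. Any claim that something is new, unique, unknown or untested is made for them only; others in the source may bear on it.

Working notes on the series.

Two members of the series have a number in a functional assay on the whole organism (Tail, strain ICR) with Mus musculus as the target, in the tail flick test, with a stated time of 60 min, at a dose of 25 umol/kg by the oral route; on this read-out higher numbers stand for a stronger effect at the one dose given and lower numbers for a weaker effect. Compound 1, `CSCC[C@H](NC(=O)CN(c1nc(Cl)nc2[nH]cnc12)C1CC1)C(=O)OCc1ccccc1`, gives 30.8% in this assay. Compound 2, `CC(C)C[C@H](NC(=O)CN(c1nc(Cl)nc2[nH]cnc12)C1CC1)C(=O)OCc1ccccc1`, gives 27.3% in this assay. The one step measured, a number 3.5 percentage points lower from compound 1 to compound 2 (within the scatter), is within the scatter, so the two numbers cannot be ordered; compound 2 simply stands with compound 1 on the numbers shown, with no gap beyond the scatter between them.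

Compound 3, `NC(=O)C[C@H](NC(=O)CN(c1nc(Cl)nc2[nH]cnc12)C1CC1)C(=O)OCc1ccccc1`, is not yet measured. Relative to compound 2 the change is carbamoyl in place of isopropyl on a saturated chain carbon, two bonds along the chain from an amide-type nitrogen and a carbonyl carbon. For the measured compounds named here, the only measured step at the same place in the chain is the one from compound 1 to compound 2, and it was within the scatter. No measured step covers an exchange of isopropyl for carbamoyl, so nothing shown points to a direction. On that basis a step of a number 2.3 percentage points lower from compound 2 to compound 3 (within the scatter) is expected, that is, none beyond the scatter, with a wide band around it.

For compound 3 the estimate in this assay is 25%, expected to lie between 8% and 42%.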

Compound 3, a percentage reported as activity, at one dose (the size of the read-out at that dose, not a potency): 36.4%
Compound 3: middle estimate off by 11.4 percentage points, on the low side; measured number inside the range.
By their numbers in this assay, from the lowest: compounds 2, 1 and 3 (each within the scatter of the next).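

In this assay the exchange of isopropyl for carbamoyl on a saturated chain carbon, two bonds along the chain from an amide-type nitrogen and a carbonyl carbon, gives no step beyond the scatter (the step is a number 9.1 percentage points higher from compound 2 to compound 3 (within the scatter)), and the exchange of (methylsulfanyl)methyl for carbamoyl at the same place gives none either (the step is a number 5.6 percentage points higher from compound 1 to compound 3 (within the scatter)). For the compounds shown here, the position therefore holds a group with a hydrogen-bond donor and a hydrogen-bond acceptor, where isopropyl has neither, and the read-out at this one dose shows no separation from the earlier compounds, so the three side chains tried here cannot be ordered. Nothing available on these compounds offers an explanation for the numbers.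

It remains open whether a carboxylic acid, an amine, a benzyl group or a longer chain at this place would give a step beyond the scatter, since no group shown so far does. A single dose also leaves open whether these compounds would separate in potency across a range of doses.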